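Compound 2 to compound 3: tolerated concentration

The source may hold more compounds than are shown below. What is called first, only, known or untested is meant among the compounds shown, and "the series" means these compounds.

For the measured compounds named here, in an ADME assay on BE(2)-C cells (Homo sapiens) for cytotoxicity, read by MTT assay, with a stated time of 20 h (a lower number here means that less compound is tolerated, a higher number that more compound is tolerated), compound 2 `CC(C)Cn1c(C(=O)N2CCC(C(=O)N(C)Cc3ccccc3)CC2)cc2ccccc21` gives 58200 nM, the only actual number so far. Compound 1 `CN(Cc1ccccc1)C(=O)C1CCN(C(=O)c2cc3ccccc3n2Cc2ccc(C#N)cc2)CC1` gives > 100000 nM, which is a limit of the assay and not a number.

Compound 3 `CN(Cc1ccccc1)C(=O)C1CCN(C(=O)c2cc3ccccc3n2Cc2ccncc2)CC1` differs from compound 2 by pyridin-4-yl in place of isopropyl on a saturated chain carbon bound to an aromatic nitrogen. Going by the values given here, one measured step bears on this place, an at least 1.7-fold lower number from compound 1 to compound 2 (0.23 log units; that floor lies within the scatter), where isopropyl replaced 4-cyanophenyl. Compound 3 restores a six-membered aromatic ring there, so a small move towards a higher number is expected, though only tentatively, since that one step is a floor within the scatter.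

The expected size is a 1.5-fold higher number from compound 2 to compound 3 (0.16 log units; within the scatter), which is not expected to clear the scatter. For compound 3 the estimate is 85000 nM, with an expected range of 35000 nM to 150000 nM.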

Compound 3, half-maximal cytotoxic concentration: 80300 nM
Compound 3: middle estimate off by 1.1-fold (0.02 log units), on the high side; measured number inside the range.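

In this assay, for the compounds shown here, pyridin-4-yl in place of isopropyl gives a 1.4-fold higher number from compound 2 to compound 3 (0.14 log units; within the scatter), the first step at this position read between two actual numbers, and it does not clear the scatter. Pyridin-4-yl in place of 4-cyanophenyl gives an at least 1.2-fold lower number from compound 1 to compound 3 (0.09 log units; that floor lies within the scatter), so these two groups cannot be ordered on this reading. Compound 1 carries a limit and not a number, which makes that step only a floor: the limit of > 100000 nM in this assay, at which 1 of the 3 values shown sits.

How far a group at this place can shift the tolerated concentration stays open, since no step shown clears the scatter and the steps from compound 1 are only floors. An amine or a carboxylic acid on the saturated chain carbon bound to an aromatic nitrogen, or a longer chain there, would show whether any group moves the number beyond the scatter.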